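Replacing methoxy with methylamino on a benzofuranyl core

The compounds below may be only part of what the source reports. "The series", "measured", "known", "first", "only" and "open" are said of these compounds alone.

Measured so far:
compound 1, `COc1ncnc2c1c(-c1cccs1)cn2[C@@H]1O[C@H](CO)[C@@H](O)[C@H]1O`: 6200 nM
compound 2, `CNc1ncnc2c1c(-c1cccs1)cn2[C@@H]1O[C@H](CO)[C@@H](O)[C@H]1O`: > 20000 nM
compound 3, `COc1ncnc2c1c(-c1cc3ccccc3o1)cn2[C@@H]1O[C@H](CO)[C@@H](O)[C@H]1O`: 13100 nM

In a functional assay on K562 cells (Homo sapiens), read by MTT assay, with a stated time of 72 h (on this read-out higher numbers stand for weaker inhibition and lower numbers for stronger inhibition), compound 1 gives 6200 nM. For compound 2 the value in this assay is a limit of the assay, > 20000 nM, and not a number (the limit of > 20000 nM in this assay, at which 1 of the 3 values shown sits). Compound 3 gives 13100 nM in this assay and so stands at the higher end of the two numbers.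

The change from compound 1 to compound 2 is methylamino in place of methoxy on an aromatic carbon; it brought an at least 3.2-fold higher number from compound 1 to compound 2 (0.50 log units; beyond the scatter). Compound 3 differs from compound 1 by 1-benzofuran-2-yl in place of thiophen-2-yl on an aromatic carbon, with a 2.1-fold higher number from compound 1 to compound 3 (0.32 log units; beyond the scatter).

Compound 4, `CNc1ncnc2c1c(-c1cc3ccccc3o1)cn2[C@@H]1O[C@H](CO)[C@@H](O)[C@H]1O`, has not yet been measured. It differs from compound 3 by methylamino in place of methoxy on an aromatic carbon, the same change as from compound 1 to compound 2, made on the core of compound 3 instead. Carrying the earlier step across, compound 4 is expected to show a 3.4-fold higher number from compound 3 to compound 4 (0.54 log units; beyond the scatter) in this assay, resting on the step from compound 1 to compound 2. Since compound 3 already gives 13100 nM, compound 4 is estimated at 45000 nM.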

Compound 4, half-maximal inhibitory concentration: > 20000 nM
Compound 4: only a limit was reported; the forecaster's own chance of this, stated with the estimate: 75%; the middle value lies beyond the limit too.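

In this assay compound 4 sits at a limit of the assay, > 20000 nM, and not at a number. The swap of methoxy for methylamino on the core of compound 3 brought an at least 1.5-fold higher number from compound 3 to compound 4 (0.18 log units; that floor lies within the scatter), so the result does not run against the earlier step, but on its own it does not show a change beyond the scatter on this second core. The two cores therefore show no reversal of the change, yet they do not show that its size carries over from one core to the other: the same change on two cores in this assay, an at least 3.2-fold higher number (0.50 log units; beyond the scatter) from compound 1 to compound 2 and an at least 1.5-fold higher number (0.18 log units; that floor lies within the scatter) from compound 3 to compound 4; the limit leaves it open whether they differ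

The comparison of thiophen-2-yl with 1-benzofuran-2-yl among the methylamino compounds also stays open, as the step from compound 2 to compound 4 cannot be read: the limit of > 20000 nM in this assay, at which 2 of the 4 values shown sit. The compounds shown also leave open how a primary amine, a dimethylamino group or a longer alkoxy chain would fare in place of the methoxy on either core.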